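The compounds below may be only part of what the source reports. "The series", "measured", "known", "first", "only" and "open" are said of these compounds alone.

Measured so far:
compound 1 `Nc1cc(N)c2nc(-c3ccccc3)c(NCc3ccc(Cl)c(Cl)c3)nc2c1` — < 100000 nM
compound 2 `CCOC(=O)[C@H](CCC(=O)O)NC(=O)c1ccc(Sc2nc3cc(N)cc(N)c3nc2-c2ccccc2)cc1` — < 100000 nM
compound 3 `Nc1cc(N)c2nc(-c3ccccc3)c(Sc3ccc(Cl)c(Cl)c3)nc2c1` — < 100000 nM

In a functional assay on UO-31 cells (Homo sapiens) for inhibition, read by sulforhodamine B assay, with a stated time of 48 h (on this read-out higher numbers stand for weaker inhibition of growth and lower numbers for stronger inhibition of growth), compound 1 gives < 100000 nM, which is a limit of the assay and not a number. Compound 2 gives < 100000 nM in this assay, again a limit. Compound 3 likewise returns < 100000 nM, also a limit. Among the measured compounds shown here, nothing therefore places compound 1 relative to the other two: all three sit at the same limit (the limit of < 100000 nM in this assay, at which 3 of the 3 values shown sit), and no step between measured compounds can be read from them.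

Compound 4 `COc1ccc(CNc2nc3cc(N)cc(N)c3nc2-c2ccccc2)cc1` has not yet been measured in this assay. It differs from compound 1 by 4-methoxyphenyl in place of 3,4-dichlorophenyl on a saturated chain carbon bound to a nitrogen on an aromatic ring. With every measured value a limit, there is no anchor for the size or direction of this change. The expected step is a step that the limit leaves unreadable from compound 1 to compound 4, that is, none beyond the usual scatter. Compound 4 is expected to give 30000 nM in this assay, with a range from 5000 nM to 100000 nM, and a further limit rather than a number is the likelier outcome.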

Compound 4, concentration for total growth inhibition: 28800 nM
Estimate against measurement, compound 4: 1.0-fold (0.02 log units) above; measured number inside the range.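

Among the compounds shown here, no step from compound 1 to compound 4 can be read in this assay, because compound 1 holds only a limit and not a number: the limit of < 100000 nM in this assay, at which 3 of the 4 values shown sit.

On these data alone, whether 4-methoxyphenyl or 3,4-dichlorophenyl gives stronger inhibition of growth, and by how much, remains open.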